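Aryl replacement at the enone position of the shared core

This account rests on a few compounds, and the source may have more. Where it says the series, first, only, none or still open, it means among the compounds named here.

Measured compounds:
compound 1 `C[C@@H](O[C@H]1CN2C(=O)C=C(c3ccc(C#N)cc3)CC2[C@@H]1c1ccc(F)cc1)c1cc(C(F)(F)F)cc(C(F)(F)F)c1`: 53 nM
compound 2 `C[C@@H](O[C@H]1CN2C(=O)C=C(c3ccc(CO)cc3)CC2[C@@H]1c1ccc(F)cc1)c1cc(C(F)(F)F)cc(C(F)(F)F)c1`: 23 nM
compound 3 `C[C@@H](O[C@H]1CN2C(=O)C=C(c3cc[n+]([O-])cc3)CC2[C@@H]1c1ccc(F)cc1)c1cc(C(F)(F)F)cc(C(F)(F)F)c1`: 2.1 nM

In an assay on CHO cells for displacement of a labelled ligand from Substance-P receptor (Homo sapiens), in the presence of a further agent that is not named here (a higher number here means a weaker inhibitor, a lower number a stronger inhibitor), compound 3 gives 2.1 nM, the lowest of the three numbers; compound 2 gives 23 nM and compound 1 gives 53 nM, both beyond the scatter away from compound 3.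

Compound 4 `Cc1cc(C2=CC(=O)N3C[C@H](O[C@H](C)c4cc(C(F)(F)F)cc(C(F)(F)F)c4)[C@@H](c4ccc(F)cc4)C3C2)ccn1` differs from compound 3 in one place: a group of 7 heavy atoms (6 carbon, 1 nitrogen; one six-membered aromatic ring with 1 hetero atom) in place of a group of 7 heavy atoms (5 carbon, 1 nitrogen, 1 oxygen; one six-membered aromatic ring with 1 hetero atom), on a double-bonded ring carbon. Going by the values given here, the measured steps that touch this position are a 25-fold lower number from compound 1 to compound 3 (1.40 log units; beyond the scatter) and an 11-fold lower number from compound 2 to compound 3 (1.04 log units; beyond the scatter), both large and both describing the arrival of the group that now leaves, which is the group behind the lowest number so far. Among the compounds with values here, no measured step shows what a 2-methylpyridin-4-yl does at this position. Since the group that leaves carried a large gain over the nitrile and hydroxymethyl phenyl groups of compound 1 and compound 2, removing it in favour of the 2-methylpyridin-4-yl is expected to give back part of that gain, so compound 4 is expected to show a moderately higher number in this assay, a step of a 3.8-fold higher number from compound 3 to compound 4 (0.58 log units; beyond the scatter). Compound 4 is therefore estimated at 8 nM, with a range from 2.5 nM to 25 nM.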

Compound 4, half-maximal inhibitory concentration: 34 nM
For compound 4 the middle estimate is 4.3-fold (0.63 log units) below the measured one; measured number above the stated range.
By their numbers in this assay, from the lowest: compound 3; then compounds 2, 4 and 1 (each within the scatter of the next, the first and the last beyond it).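

In this assay the step to the 2-methylpyridin-4-yl is a 16-fold higher number from compound 3 to compound 4 (1.21 log units; beyond the scatter), which shows that a six-membered aromatic ring with 1 hetero atom at this double-bonded ring carbon does not by itself keep the low number: the oxygen-bearing ring of compound 3 stands apart from this closely similar ring. Set against the two phenyl groups, the same replacement gives a 1.5-fold higher number from compound 2 to compound 4 (0.17 log units; within the scatter) and a 1.6-fold lower number from compound 1 to compound 4 (0.19 log units; within the scatter), so the ring nitrogen of the 2-methylpyridin-4-yl separates it from neither 4-(hydroxymethyl)phenyl nor 4-cyanophenyl, and of the four groups only that of compound 3 stands out. Nothing given here bears on why the number moves in this way.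

The compounds shown leave open whether the step from compound 3 goes with the loss of the oxygen or with the arrival of the methyl, a question that a plain pyridin-4-yl at this carbon would address. They also leave open how a ring carrying an amine or a carboxylic acid would compare at this position.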